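This account rests on a few compounds, and the source may have more. Where it says the series, first, only, none or still open, it means among the compounds named here.

Compound 1 `COC(=O)c1c(N)sc(-c2ccc(Cl)cc2)c1-c1ccc(Cl)cc1`, compound 2 `Nc1sc(-c2ccc(Cl)cc2)c(-c2ccc(Cl)cc2)c1C(=O)NC1CC1` and compound 3 `Nc1sc(-c2ccc(Cl)cc2)c(-c2ccc(Cl)cc2)c1C(=S)NC1CC1` share one core and were tested in a functional assay on PC-3 cells (Homo sapiens) for cytotoxicity, read by sulforhodamine B assay, with a stated time of 72 h; on this read-out lower numbers stand for stronger inhibition and higher numbers for weaker inhibition. In this assay compound 1 gives 2780 nM. Compound 2 gives 3680 nM. Compound 3 gives 22100 nM, the highest of the three numbers. Going by the values given here, the step of a 1.3-fold higher number from compound 1 to compound 2 (0.12 log units; within the scatter) lies within the scatter, while a 7.9-fold higher number from compound 1 to compound 3 (0.90 log units; beyond the scatter) and a 6.0-fold higher number from compound 2 to compound 3 (0.78 log units; beyond the scatter) lie beyond it, so the exchange of carbonyl for thiocarbonyl is the only change so far that moved the number.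

Compound 4 `CC(C)(C)NC(=S)c1c(N)sc(-c2ccc(Cl)cc2)c1-c1ccc(Cl)cc1` differs from compound 3 by tert-butyl in place of cyclopropyl on an amide-type nitrogen. Among the compounds with values here, none of the measured steps touches the group on the amide-type nitrogen: the three steps concern the methoxy, the cyclopropylamino and the carbonyl against the thiocarbonyl, so no direct guide to this change exists. The thiocarbonyl of compound 3 is kept in compound 4. Compound 4 is therefore expected to show a 1.0-fold lower number from compound 3 to compound 4 (0.00 log units; within the scatter), no step beyond the scatter. The estimate for compound 4 is 22000 nM, with a range from 8000 nM to 60000 nM.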

Compound 4, half-maximal inhibitory concentration: 34000 nM
For compound 4 the middle estimate is 1.5-fold (0.19 log units) below the measured one; low and high end bracket the measured number.
By their numbers in this assay, from the lowest: compounds 1 and 2 (each within the scatter of the next); then compounds 3 and 4 (each within the scatter of the next).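

In this assay, exchanging cyclopropyl for tert-butyl on the amide-type nitrogen, the only variation of this group among the compounds shown, gives a 1.5-fold higher number from compound 3 to compound 4 (0.19 log units; within the scatter) and so leaves compound 3 and compound 4 level: with the thiocarbonyl kept, a ring and an open branched group on this nitrogen read alike. Going by these compounds alone, the separation of the thiocarbonyl compounds from compound 1 and compound 2 holds with either group, since a 9.2-fold higher number from compound 2 to compound 4 (0.97 log units; beyond the scatter) and a 12-fold higher number from compound 1 to compound 4 (1.09 log units; beyond the scatter) both lie beyond the scatter, and the second of these is the largest step so far. No measurement offered here accounts for these numbers. The compounds shown leave open whether methyl, a longer chain such as n-butyl, or a chain ending in an amine on this nitrogen would read differently. They also leave open whether tert-butyl would read the same with a carbonyl in place of the thiocarbonyl.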